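Chloro in Place of Methoxy on Two Related Cores

This account rests on a few compounds, and the source may have more. Where it says the series, first, only, none or still open, it means among the compounds named here.

Compound 1, `CCCCC#Cc1c(C)[nH]c2ccc(OC)cc2c1=O`, in an ADME assay for permeability, using PAMPA, at pH 4 (a lower number here means that the compound crosses the layer more slowly, a higher number that the compound crosses the layer faster), gives 1020 10^-6 cm/s.
Compound 2, `CCCCC#Cc1c(C)[nH]c2ccc(Cl)cc2c1=O`, in this assay gives 171 10^-6 cm/s.
Compound 3, `COc1cccc2c(=O)c(Cc3ccccc3)c(C)[nH]c12`, in this assay gives 164 10^-6 cm/s.

Within the data shown here, the one single-point change measured so far is chloro in place of methoxy on an aromatic carbon, and it made a 6.0-fold lower number from compound 1 to compound 2 (0.78 log units; beyond the scatter). Compound 3 carries a different core from compound 1; the difference between the two cores is not broken down here. The number for compound 3 and the number for compound 2 lie within the usual scatter of each other, so nothing separates them.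

Compound 4, `Cc1[nH]c2c(Cl)cccc2c(=O)c1Cc1ccccc1`, has not yet been measured. It differs from compound 3 by chloro in place of methoxy on an aromatic carbon. Among the measured compounds shown here, this is the same kind of change as the one from compound 1 to compound 2, but not the same: in the earlier pair the site was meta to a fused ring and para to a fused ring, whereas here it is ortho to a fused ring and meta to a fused ring.

The expectation for compound 4 rests on a single precedent, the step of a 6.0-fold lower number from compound 1 to compound 2 (0.78 log units; beyond the scatter) on a different core and at a different site, so the estimate is held loosely. Compound 4 is expected to give 40 10^-6 cm/s in this assay, with a likely range of 12 10^-6 cm/s to 130 10^-6 cm/s. That estimate means an expected step of a 4.1-fold lower number from compound 3 to compound 4 (0.61 log units; beyond the scatter), in the direction of the earlier step because of a 6.0-fold lower number from compound 1 to compound 2 (0.78 log units; beyond the scatter).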

Compound 4, apparent permeability: 430 10^-6 cm/s
For compound 4 the middle estimate is 11-fold (1.03 log units) below the measured one; measured number outside the range, above it.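

In this assay, chloro in place of methoxy on an aromatic carbon gave a 2.6-fold higher number from compound 3 to compound 4 (0.42 log units; beyond the scatter), so the change did not carry over from one core to the other, and the two steps run in opposite directions: the same change on two cores in this assay, a 6.0-fold lower number (0.78 log units; beyond the scatter) from compound 1 to compound 2 and a 2.6-fold higher number (0.42 log units; beyond the scatter) from compound 3 to compound 4, 16-fold (1.19 log units) apart, beyond the scatter of two such steps

This shows that, on these two pairs, the step measured on the core of compound 1 could not be used to read the step on the core of compound 3, not even for its direction. It does not show what separates the two results, as the pairs differ both in the core and in the site of the change, which is meta to a fused ring and para to a fused ring in compound 2 but ortho to a fused ring and meta to a fused ring in compound 4, and these two pairs cannot tell those differences apart.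

The compounds shown leave open whether the same change at one matching site on both cores would give steps that agree. They also leave open how other groups at these sites, such as fluoro, an amine or a carboxylic acid, would compare with chloro and methoxy in this assay.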